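Rejoining the group on sulfur: what compound 4 may show

The source may hold more compounds than are shown below. What is called first, only, known or untested is meant among the compounds shown, and "the series" means these compounds.

Three measured compounds share one core and differ only in the group on a sulfur: compound 1 (`CCCCCCCN(CCCCCSc1ncccn1)C(=O)Nc1ccc(F)cc1F`), compound 2 (`CCCCCCCN(CCCCCSc1nc(N)c2c[nH]nc2n1)C(=O)Nc1ccc(F)cc1F`) and compound 3 (`CCCCCCCN(CCCCCSc1[nH]cnc2ncnc1-2)C(=O)Nc1ccc(F)cc1F`). In a physicochemical assay for lipophilicity (a lower number here means a more polar compound, a higher number a more lipophilic compound), compound 1 stands at 5.41 and compound 2 at 5.74 while compound 3 reads 5.32 on the same scale. Compound 3 thus cannot be told apart from compound 1, and compound 2 lies clear of both.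

The next compound is compound 4 (`CCCCCCCN(CCCCCSc1[nH]cnc2nncc1-2)C(=O)Nc1ccc(F)cc1F`). The structural change is a group of 9 heavy atoms (5 carbon, 4 nitrogen; one five-membered aromatic ring with 2 hetero atoms, one six-membered aromatic ring with 2 hetero atoms) in place of a group of 9 heavy atoms (5 carbon, 4 nitrogen; one five-membered aromatic ring with 2 hetero atoms, one six-membered aromatic ring with 2 hetero atoms), on a sulfur and the two have the same atoms, joined differently, with no net charge on either group.

Among the measured compounds shown here, no measured step is of this kind, so the evidence is indirect. The three swaps at the same place are a number 0.33 log units higher from compound 1 to compound 2 (beyond the scatter) and a number 0.09 log units lower from compound 1 to compound 3 (within the scatter) and a number 0.42 log units lower from compound 2 to compound 3 (beyond the scatter) as well. Each of these replaces one group with another of a different size, and none is more than modest. A rejoining of the same atoms is therefore expected to give no step beyond the scatter in this assay and no direction is favoured. The estimated step is a number 0.03 log units higher from compound 3 to compound 4 (within the scatter) and so stays small. For compound 4 the estimate is 5.35 with an expected range from 5 to 5.75 as its span.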

Compound 4, partition coefficient: 5.6
Estimate against measurement, compound 4: 0.25 log units below; measured number inside the range.
By their numbers in this assay, from the lowest: compounds 3, 1, 4 and 2 (each within the scatter of the next, the first and the last beyond it).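

In this assay, this is the only step shown between two groups of the same atoms and the same counts of donors and acceptors, and the rejoining stays inside the scatter, with a number 0.28 log units higher from compound 3 to compound 4 (within the scatter). Compound 4 also cannot be told apart from the other two compounds, with a number 0.14 log units lower from compound 2 to compound 4 (within the scatter) and a number 0.19 log units higher from compound 1 to compound 4 (within the scatter). It therefore falls within the scatter of both compound 2 and compound 3, although those two remain separated by more than the scatter, and the new group forms no separate level at this place on the sulfur. Nothing shown here gives a reason for where compound 4 falls.

One pair sets no general rule for rejoinings of these atoms, and another arrangement of the same atoms could still give a step beyond the scatter. The compounds shown also leave open how this series would read with a carboxylic acid or a morpholine on the sulfur, or with a longer chain in place of the one that carries the sulfur.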